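This account rests on a few compounds, and the source may have more. Where it says the series, first, only, none or still open, it means among the compounds named here.

Measured compounds:
compound 1 `CC(C)N(Cc1cccc(OCCCCCC(=O)O)c1)C(=O)c1ccc(-c2cc3ccccc3n2S(=O)(=O)c2ccccc2)cc1`: > 26000 nM
compound 2 `CCOC(=O)CCCCCOc1cccc(CN(C(=O)c2ccc(-c3ccc(C(C)=O)s3)cc2)C(C)C)c1`: > 26000 nM

In an ADME assay on BJ cells (Homo sapiens) for cytotoxicity, read by CellTiter-Glo and resazurin assay, with a stated time of 72 h (on this read-out higher numbers stand for an effect only at larger amounts of compound and lower numbers for an effect already at smaller amounts), compound 1 gives only a limit, > 26000 nM. Compound 2 likewise gives only a limit in this assay, > 26000 nM. For the measured compounds named here, both values sit at the limit of > 26000 nM in this assay, at which 2 of the 2 values shown sit, and no step between measured compounds can be read from them. Compound 3 `CCOC(=O)CCCCCOc1cccc(CN(C(=O)c2ccc(-c3cccc([N+](=O)[O-])c3)cc2)C(C)C)c1` differs from compound 2 in one place: 3-nitrophenyl in place of 5-acetylthiophen-2-yl on an aromatic carbon. Going by the values given here, with no measured step to go by, no change beyond the scatter is expected in this assay. Compound 3 is expected to give 30000 nM (range 15000 nM to 60000 nM), most likely again reported as a limit. The expected step that the limit leaves unreadable from compound 2 to compound 3 is within the scatter.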

Compound 3, half-maximal effective concentration: < 1.3 nM
Compound 3 gave a limit, no number (the forecaster's own chance of this, stated with the estimate: 80%); middle value at least 23000-fold (4.36 log units) away from the limit.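

In this assay, 3-nitrophenyl in place of 5-acetylthiophen-2-yl on an aromatic carbon, para to a large group, gives an at least 20000-fold lower number from compound 2 to compound 3 (4.30 log units; beyond the scatter). For the compounds shown here, this position can therefore move the read-out across the whole measured span, which the earlier compounds, both at one limit, could not show. Compound 3 gives only a limit, at the opposite end: the limit of < 1.3 nM in this assay, at which 1 of the 3 values shown sits.

On these data alone, whether the nitro group or the carbon-only ring carries the step stays open. A plain phenyl, or an amine or nitrile in place of the nitro group, would separate the two.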